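Capping the hydroxy group of compound 1 with propargyl

The source may hold more compounds than are shown below. What is called first, only, known or untested is meant among the compounds shown, and "the series" means these compounds.

Among the compounds with values here, in a functional assay on HeLa cells (Homo sapiens) for cytotoxicity, read by sulforhodamine B assay, with a stated time of 72 h (a lower number here means a stronger inhibitor, a higher number a weaker inhibitor), compound 1 `COc1cc(NC(=O)/C=C/c2cccc(O)c2)cc(OC)c1OC` gives 18700 nM, the higher of the two numeric values so far. Compound 3 `COc1ccccc1/C=C/C(=O)Nc1cc(OC)c(OC)c(OC)c1` gives 6100 nM. Compound 2 `COc1cc(/C=C/C(=O)Nc2ccccc2)cc(OC)c1OC` reads > 50000 nM, which is a limit of the assay and not a number.

The next compound to be read is compound 4 `C#CCOc1cccc(/C=C/C(=O)Nc2cc(OC)c(OC)c(OC)c2)c1`, which turns hydroxy to propargyloxy on compound 1: propargyl in place of hydrogen on an oxygen on an aromatic ring. Within the data shown here, one measured step bears on this change: a 3.1-fold lower number from compound 1 to compound 3 (0.49 log units; beyond the scatter). Among the measured compounds shown here, that step also removes the free hydroxy group, but it puts 2-methoxyphenyl in place of 3-hydroxyphenyl, so it is only a partial guide, and no measured compound carries propargyl. A modest move to a lower number in this assay is therefore expected, of about the size of that step or smaller, and it may not clear the scatter. The expected step is a 1.9-fold lower number from compound 1 to compound 4 (0.27 log units; within the scatter). For compound 4 the estimated value is 10000 nM, with an expected range of 3000 nM to 35000 nM.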

Compound 4, half-maximal inhibitory concentration: 2000 nM
Compound 4: the middle estimate sits 5.0-fold (0.70 log units) above what was measured; the measured number lies below the stated range.
By their numbers in this assay, from the lowest: compound 4; then compound 3; then compound 1. At a limit, above all of these: compound 2.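

In this assay the change of hydroxy to propargyloxy gives a 9.4-fold lower number from compound 1 to compound 4 (0.97 log units; beyond the scatter), so the oxygen on the aromatic ring of compound 1 tolerates a propargyl cap, and the number falls with it. The earlier step, a 3.1-fold lower number from compound 1 to compound 3 (0.49 log units; beyond the scatter), put 2-methoxyphenyl in place of 3-hydroxyphenyl and so changed more than the group on this oxygen, whereas here the rest of compound 1 stays fixed and the step can be read as that of the cap alone. Nothing in hand accounts for the size of this step.

Still open, on these data alone, is whether the lower number follows from losing the hydroxy hydrogen or from the propargyl group itself. A methyl or a saturated propyl chain on the same oxygen would separate the two, and a longer chain ending in an amine or a carboxylic acid would test how much this position accepts.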